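Dimethylamino in Place of 2-Fluorophenyl: An Expected Recovery

A few compounds are considered here, and "the series" means these few. Any claim that something is new, unique, unknown or untested is made for them only; others in the source may bear on it.

Compound 3 `O=C(CCCCCCc1nc2ccc(-c3ccccc3F)cc2[nH]1)NO` stands highest of the three measured numbers in a functional assay on SK-OV-3 cells (Homo sapiens) for cytotoxicity (on this read-out lower numbers stand for stronger inhibition and higher numbers for weaker inhibition), giving 7400 nM. Compound 1 `O=C(CCCCCCc1nc2ccc(Cl)cc2[nH]1)NO` gives 320 nM and compound 2 `O=C(CCCCCCc1nc2ccc(-c3ccccc3)cc2[nH]1)NO` gives 100 nM. The steps of a 23-fold higher number from compound 1 to compound 3 (1.36 log units; beyond the scatter) and a 74-fold higher number from compound 2 to compound 3 (1.87 log units; beyond the scatter) show that the group at this position moves the number strongly, while a 3.2-fold lower number from compound 1 to compound 2 (0.51 log units; beyond the scatter) is a modest shift. Compound 4 `CN(C)c1ccc2nc(CCCCCCC(=O)NO)[nH]c2c1` differs from compound 3 in one place: dimethylamino in place of 2-fluorophenyl on an aromatic carbon. Dimethylamino has no measured precedent here, so the size of the step is uncertain. Since the 2-fluorophenyl carried the large loss seen in a 74-fold higher number from compound 2 to compound 3 (1.87 log units; beyond the scatter), its removal is expected to bring compound 4 back toward lower numbers, estimated as a 15-fold lower number from compound 3 to compound 4 (1.17 log units; beyond the scatter). Compound 4 is therefore estimated at 500 nM, with a range of 100 nM to 3000 nM.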

Compound 4, half-maximal inhibitory concentration: 1200 nM
Beside the measured number, compound 4's estimate is 2.4-fold (0.38 log units) below it; measured number inside the range.
By their numbers in this assay, from the lowest: compound 2; then compound 1; then compound 4; then compound 3.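

In this assay, dimethylamino recovers only part of the loss seen with 2-fluorophenyl (a 6.2-fold lower number from compound 3 to compound 4 (0.79 log units; beyond the scatter)). It still falls short of phenyl (a 12-fold higher number from compound 2 to compound 4 (1.08 log units; beyond the scatter)) and of chloro (a 3.8-fold higher number from compound 1 to compound 4 (0.57 log units; beyond the scatter)), so removing the 2-fluorophenyl ring is not enough to reach the lower numbers at this aromatic carbon, and compound 4 ranks behind both compounds 1 and 2. Nothing measured here explains this order of groups. As far as these compounds go, it remains open whether a methoxy group, a morpholine ring or a primary amine at this carbon would behave like dimethylamino.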